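Swapping a methyl for an acetyl on a sugar oxygen

The source may report more compounds than this note shows. Statements on the series, on what has been measured and on what is new or still open speak of the compounds shown alone.

Measured so far in an ADME assay on Vero cells (Chlorocebus sabaeus) for cytotoxicity, read by MTT assay, with a stated time of 48 h; on this read-out higher numbers stand for lower toxicity in this test and lower numbers for higher toxicity in this test:
- compound 1, `CO[C@@H]1[C@H]2OC(C)(C)O[C@H]2O[C@@H]1C(=O)c1cnc2sc(C(=O)c3ccccc3)cn12`, gives > 400000 nM
- compound 2, `CO[C@@H]1[C@H]2OC(C)(C)O[C@H]2O[C@@H]1C(=O)c1cnc2sc(C(=O)c3ccc(Br)cc3)cn12`, gives 295000 nM
- compound 3, `CO[C@@H]1[C@H]2OC(C)(C)O[C@H]2O[C@@H]1C(=O)c1cnc2sc(C(=O)c3ccc(Cl)cc3)cn12`, gives 371000 nM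

Compound 1 sits at a limit of this assay, not at a number: its value of > 400000 nM marks the top of what was tested, as the limit of > 400000 nM in this assay, at which 1 of the 3 values shown sits, records. Compounds 2 and 3 carry bromo or chloro in place of hydrogen on an aromatic carbon, and their steps, an at least 1.3-fold lower number from compound 1 to compound 2 (0.13 log units; that floor lies within the scatter), an at least 1.0-fold lower number from compound 1 to compound 3 (0.03 log units; that floor lies within the scatter) and a 1.3-fold higher number from compound 2 to compound 3 (0.10 log units; within the scatter), all lie within the scatter; every measured compound shows low toxicity here.

Compound 4, `CC(=O)O[C@@H]1[C@H]2OC(C)(C)O[C@H]2O[C@@H]1C(=O)c1cnc2sc(C(=O)c3ccccc3)cn12`, differs from compound 1 in another place: acetyl in place of methyl on an oxygen on a saturated carbon. Going by the values given here, none of the measured steps touches this position, so they give no direct guide; they only show that small changes elsewhere left the read-out near the limit. A step of no size beyond the scatter is therefore expected, and compound 4 is estimated at 400000 nM, with a range from 200000 nM to 800000 nM, meaning an expected step of a number no higher from compound 1 to compound 4 (the limit leaves the size open).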

Compound 4, half-maximal cytotoxic concentration: > 400000 nM
Compound 4 gave a limit, no number (the forecaster's own chance of this, stated with the estimate: 60%); the middle value lies on the limit itself.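

In this assay, going by these compounds alone, compound 1 and compound 4 each give a limit and not a number, so no step between them can be read. The compounds shown leave open whether acetoxy in place of methoxy changes this read-out at all, and in which direction.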